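A few compounds are considered here, and "the series" means these few. Any claim that something is new, unique, unknown or untested is made for them only; others in the source may bear on it.

Measured so far:
compound 1 `O=C(CSCc1nc2cc([N+](=O)[O-])ccc2[nH]1)c1ccc(Br)cc1` — 1550 nM
compound 2 `N#Cc1sc(Nc2ccccc2)nc1NC(=O)CSCc1nc2cc([N+](=O)[O-])ccc2[nH]1` — 11300 nM

In a functional assay on MCF7 cells (Homo sapiens) for cytotoxicity, read by MTT assay, with a stated time of 48 h (a higher number here means a weaker inhibitor, a lower number a stronger inhibitor), compound 1 gives 1550 nM, the lowest of the two numbers; compound 2 gives 11300 nM, a higher number that lies beyond the scatter. Compound 3 `NC(=O)CSCc1nc2cc([N+](=O)[O-])ccc2[nH]1` has not yet been measured. It differs from compound 1 by amino in place of 4-bromophenyl on a carbonyl carbon. Among the measured compounds shown here, no measured pair shows what such a change does here, so the direction is judged from the structures alone: the step from compound 1 to compound 3 is expected to be upward, a clear loss of potency beyond the scatter, a 5.2-fold higher number from compound 1 to compound 3 (0.71 log units; beyond the scatter). For compound 3 the estimate in this assay is 8000 nM, within 2500 nM to 30000 nM.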

Compound 3, half-maximal inhibitory concentration: 19700 nM
Compound 3: the middle estimate sits 2.5-fold (0.39 log units) below what was measured; low and high end bracket the measured number.
By their numbers in this assay, from the lowest: compound 1; then compounds 2 and 3 (each within the scatter of the next).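

In this assay, the group on the carbonyl carbon clearly matters: putting amino in place of 4-bromophenyl gives a 13-fold higher number from compound 1 to compound 3 (1.10 log units; beyond the scatter), a large loss of potency. The core of compound 1 therefore still gives a measurable number with only amino at this place, but much of the potency of compound 1 depends on 4-bromophenyl being there. Nothing at hand says why the potency falls.

On these data alone, it remains open whether the ring or the bromine matters more. A plain phenyl or a 4-chlorophenyl on the same carbonyl carbon would help separate the two.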